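The compounds below may be only part of what the source reports. "The series", "measured", "known", "first", "only" and "open" are said of these compounds alone.

Measured compounds:
compound 1, `Cc1ccc2c(NCc3ccc(NC(=O)C4CCN(Cc5ncc[nH]5)CC4)cc3)nc(N(C)C)nc2c1` — > 20000 nM in a functional assay on SV5A8 cells (Homo sapiens) for cytotoxicity; on this read-out higher numbers stand for weaker inhibition and lower numbers for stronger inhibition
compound 2, `Cc1ccc2c(NCc3ccc(NC(=O)C4CCN(Cc5ccccc5F)CC4)cc3)nc(N(C)C)nc2c1` — > 6670 nM in this assay

The value for compound 1 is a limit of the assay, > 20000 nM. The value for compound 2 is likewise a limit of the assay, > 6670 nM. Because both sit at limits, as the limit of > 20000 nM in this assay, at which 1 of the 2 values shown sits, and the limit of > 6670 nM in this assay, at which 1 of the 2 values shown sits, show, the step that the two limits leave unreadable from compound 1 to compound 2 cannot be read, and compound 2 stands only at a limit, with no numerical position on this read-out.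

Compound 3, `Cc1ccc2c(NCc3ccc(NC(=O)C4CCN(Cc5ccc(F)cc5Cl)CC4)cc3)nc(N(C)C)nc2c1`, differs from compound 2 by 2-chloro-4-fluorophenyl in place of 2-fluorophenyl on a saturated chain carbon bound to an amine nitrogen in a ring. Among the compounds with values here, the only measured step that touches this position, from compound 1 to compound 2, is unreadable, so no size can be drawn from it; a related change at the same saturated chain carbon gave no value that left the limit. Compound 3 is therefore expected to stay near or at the limit. The expected step is a step that the limit leaves unreadable from compound 2 to compound 3, within the scatter. Compound 3 is estimated at 15000 nM, in a range from 4000 nM to 60000 nM.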

Compound 3, half-maximal inhibitory concentration: > 5910 nM
Compound 3: no number, only a limit; the forecaster's own chance of this, stated with the estimate: 75%; the middle value is on the limit's open side.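

Compound 3, like compound 2 and compound 1, stands only at a limit in this assay, so no step can be read from compound 3 to either of the other two. The compounds shown leave open what numerical value any of them would have, and whether the groups compared differ at all on this read-out.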